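The source may report more compounds than this note shows. Statements on the series, on what has been measured and on what is new or still open speak of the compounds shown alone.

Compound 2 `CNC(=O)N1CCCc2ccc(NC(=O)c3cccc(-c4cnn(C)c4)c3)cc21` gives 71.2% in a functional assay on MV4-11 cells (Homo sapiens) for antiproliferative activity, with a stated time of 6 days, tested at 1.56 uM (a lower number here means a weaker effect, a higher number a stronger effect of the compound at the concentration tested), the highest of the three numbers measured. Compound 1 `CNC(=O)N1CCCc2ccc(NC(=O)c3ccc(-c4ccccc4)cc3)cc21` gives 19.7% and compound 3 `CNC(=O)N1CCCc2ccc(NC(=O)c3ccc(-c4ccncc4)cc3)cc21` gives 37.6% in this assay, both beyond the scatter below compound 2. Among the compounds with values here, the only measured single step, a number 17.9 percentage points higher from compound 1 to compound 3 (beyond the scatter), concerns a six-membered ring and not the change now considered. Compound 4 `CNC(=O)N1CCCc2ccc(NC(=O)c3cccc(-c4cc[nH]n4)c3)cc21` differs from compound 2 in one place: 1H-pyrazol-3-yl in place of 1-methyl-1H-pyrazol-4-yl on an aromatic carbon. Within the data shown here, no measured step bears directly on this change, so no direction beyond the scatter can be expected with confidence, though a small loss is taken as somewhat more likely than a gain. Compound 4 is therefore expected to give 60% in this assay, with a range from 35% to 85%. The expected step is a number 11.2 percentage points lower from compound 2 to compound 4 (beyond the scatter).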

Compound 4, a percentage reported as inhibition, at one concentration (the size of the read-out at that concentration, not a potency): 27.3%
For compound 4 the middle estimate is 32.7 percentage points above the measured one, outside the stated range (below it).
By their numbers in this assay, from the lowest: compounds 1 and 4 (each within the scatter of the next); then compound 3; then compound 2.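

At the aromatic carbon meta to a large group, the two pyrazole rings are not interchangeable in this assay: 1H-pyrazol-3-yl in place of 1-methyl-1H-pyrazol-4-yl gives a number 43.9 percentage points lower from compound 2 to compound 4 (beyond the scatter), a large step. Sharing a five-membered aromatic ring with two hetero atoms is therefore not enough to keep the read-out at this place. Nothing available explains the step. The change removes the methyl group and moves the point of attachment together, and the compounds shown do not separate these two. That leaves open how 1H-pyrazol-4-yl or 1-methyl-1H-pyrazol-3-yl would behave at this position.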